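Chloro for methyl on the indole of compound 2

The source may report more compounds than this note shows. Statements on the series, on what has been measured and on what is new or still open speak of the compounds shown alone.

For the measured compounds named here, compound 2 `COC(=O)[C@@]1(C)CCC=C2[C@@H]1CC[C@@H](C)[C@]2(C)Cc1c[nH]c2ccc(C)cc12` gives 14000 nM in a functional assay on HeLa cells (Homo sapiens) for inhibition, read by sulforhodamine B assay, with a stated time of 48 h (a higher number here means a weaker inhibitor of growth, a lower number a stronger inhibitor of growth), the higher of the two numbers known; compound 1 `COC(=O)[C@@]1(C)CCC=C2[C@@H]1CC[C@@H](C)[C@]2(C)Cc1c[nH]c2ccccc12` gives 3600 nM. Going by the values given here, the one measured step, a 3.9-fold higher number from compound 1 to compound 2 (0.59 log units; beyond the scatter), concerns methyl for hydrogen and touches the same aromatic carbon, but no measured step covers chloro against methyl. Compound 3 `COC(=O)[C@@]1(C)CCC=C2[C@@H]1CC[C@@H](C)[C@]2(C)Cc1c[nH]c2ccc(Cl)cc12` differs from compound 2 by chloro in place of methyl on an aromatic carbon. With the site shown to matter yet no direct precedent, a step near or modestly below the scatter is expected, a 1.4-fold lower number from compound 2 to compound 3 (0.15 log units; within the scatter). Compound 3 is therefore estimated at 10000 nM, ranging from 3000 nM to 30000 nM.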

Compound 3, concentration for 50% growth inhibition: 11000 nM
For compound 3 the middle estimate is 1.1-fold (0.04 log units) below the measured one; measured number inside the range.
By their numbers in this assay, from the lowest: compound 1; then compounds 3 and 2 (each within the scatter of the next).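

In this assay, chloro and methyl on this aromatic carbon are not told apart, since a 1.3-fold lower number from compound 2 to compound 3 (0.10 log units; within the scatter) is the whole of the swap. With a 3.1-fold higher number from compound 1 to compound 3 (0.49 log units; beyond the scatter) for chloro in place of hydrogen, both substituents shown on this carbon now give a higher number than hydrogen, so the loss seen with methyl is not confined to that one group. No evidence bears on why the two groups give such similar numbers. Going by these compounds, what an amine, a hydroxyl or a carboxylic acid would do on this same carbon remains open.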